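The source may report more compounds than this note shows. Statements on the series, on what has been measured and on what is new or still open speak of the compounds shown alone.

Of the compounds shown here, three sharing one core have been tested in a functional assay on HCT-116 cells (Homo sapiens) for antiproliferative activity, read by MTT assay, with a stated time of 72 h; a higher number here means a weaker inhibitor, a lower number a stronger inhibitor. Compound 1 `C=CC(=O)Nc1nc(-c2ccccc2)cs1`, which keeps the amide hydrogen, gives 18600 nM. Compound 2 `C=CC(=O)N(Cc1ccccc1)c1nc(-c2ccccc2)cs1`, with benzyl on that nitrogen, reads > 30000 nM, which is a limit of the assay and not a number. Compound 3 `C=CC(=O)N(CC(=O)OC(C)(C)C)c1nc(-c2ccccc2)cs1`, with (tert-butoxycarbonyl)methyl on the same nitrogen, gives 20900 nM. The measured change here is a 1.1-fold higher number from compound 1 to compound 3 (0.05 log units; within the scatter), so these two values cannot be told apart.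

Compound 4 `C=CC(=O)N(CC(=O)NC1COC1)c1nc(-c2ccccc2)cs1` differs from compound 3 in one place: (oxetan-3-yl)amino in place of tert-butoxy on a carbonyl carbon. In plain terms, the tert-butoxycarbonyl becomes (oxetan-3-yl)carbamoyl.

Among the compounds with values here, no measured step makes this exact swap, so the closest guides are the changes made on the shared nitrogen. Besides the step already given, these are an at least 1.6-fold higher number from compound 1 to compound 2 (0.20 log units; that floor lies within the scatter) and an at least 1.4-fold lower number from compound 2 to compound 3 (0.15 log units; that floor lies within the scatter). Both are only floors, set by the limit reading of compound 2, and neither shows a change beyond the scatter.

On that basis, no step beyond the scatter is expected in this assay, in either direction, and the estimated change is a 1.1-fold higher number from compound 3 to compound 4 (0.02 log units; within the scatter). Compound 4 could also end at the limit of > 30000 nM in this assay, at which 1 of the 3 values shown sits. The estimate for compound 4 is 22000 nM, with an expected range of 11000 nM to 42000 nM.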

Compound 4, half-maximal inhibitory concentration: 20800 nM
Compound 4: middle estimate off by 1.1-fold (0.02 log units), on the high side, within the range that was stated.
By their numbers in this assay, from the lowest: compounds 1, 4 and 3 (each within the scatter of the next). At a limit, above all of these: compound 2.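

In this assay, (oxetan-3-yl)amino can replace tert-butoxy on this carbonyl carbon, bringing in a hydrogen-bond donor and a four-membered non-aromatic ring, with no readable effect: the result is a 1.0-fold lower number from compound 3 to compound 4 (0.00 log units; within the scatter), and against the compound that keeps the amide hydrogen it is a 1.1-fold higher number from compound 1 to compound 4 (0.05 log units; within the scatter). Compound 2 reads as a limit and not a number: the limit of > 30000 nM in this assay, at which 1 of the 4 values shown sits. Its step is therefore only a floor, an at least 1.4-fold lower number from compound 2 to compound 4 (0.15 log units; that floor lies within the scatter), and it does not tell how far the benzyl and (oxetan-3-yl)carbamoyl groups lie apart.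

On these data alone, compounds 1, 3 and 4 all sit within the scatter of one another, so it remains open whether any group placed on this carbonyl carbon moves the number in this assay at all. A carboxylic acid or a dimethylamino group at that place, or a longer chain in place of the saturated chain carbon, would test this, and the compounds shown do not say how any of these would read.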